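The source may hold more compounds than are shown below. What is called first, only, known or untested is meant among the compounds shown, and "the series" means these compounds.

Compound 3 `CCCCCCCCCCCCCCCCCCNC(=O)[C@@H](NC(=O)c1ccco1)[C@@H](C)O` sits at the edge of what a functional assay on SW-620 cells (Homo sapiens) for cytotoxicity, read by MTT assay, with a stated time of 48 h (a lower number here means a stronger inhibitor, a higher number a weaker inhibitor), can report: its result, > 200000 nM, is a limit rather than a number (the limit of > 200000 nM in this assay, at which 1 of the 3 values shown sits). Among the compounds with values here, compound 1 `CCCCCCCCCCCCCCCCCCNC(=O)[C@@H](N)[C@@H](C)O`, with a free amine, gives 21400 nM in this assay, and the single measured step that touches this site is an at least 9.3-fold higher number from compound 1 to compound 3 (0.97 log units; beyond the scatter). Compound 2 `CCCCCCCCCCCCCCNC(=O)[C@@H](NC(=O)c1cc2ccccc2[nH]1)[C@@H](C)O`, carrying the indole amide on a shorter chain, gives 15200 nM in this assay. Compound 4 `CCCCCCCCCCCCCCCCCCNC(=O)[C@@H](NC(=O)c1cc2ccccc2[nH]1)[C@@H](C)O` differs from compound 3 by 1H-indol-2-yl in place of furan-2-yl on a carbonyl carbon. Given that compound 2 reaches 15200 nM, compound 4 is expected to fall back into the measurable range, with a step estimated as an at least 9.0-fold lower number from compound 3 to compound 4 (0.95 log units; beyond the scatter). Compound 4 is therefore estimated at 22000 nM in this assay, most likely between 8000 nM and 90000 nM.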

Compound 4, half-maximal inhibitory concentration: 23600 nM
Compound 4: the middle estimate sits 1.1-fold (0.03 log units) below what was measured; measured number inside the range.
By their numbers in this assay, from the lowest: compounds 2, 1 and 4 (each within the scatter of the next). At a limit, above all of these: compound 3.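

In this assay, putting 1H-indol-2-yl in place of furan-2-yl gives an at least 8.4-fold lower number from compound 3 to compound 4 (0.92 log units; beyond the scatter), so the loss at this amine nitrogen belongs to the furan-2-yl amide and not to acylation as such. The (1H-indol-2-yl)carbonyl group leaves the result level with the free amine, a 1.1-fold higher number from compound 1 to compound 4 (0.04 log units; within the scatter), and adding butyl to the chain also changes nothing beyond the scatter, a 1.6-fold higher number from compound 2 to compound 4 (0.19 log units; within the scatter). The result for compound 3 remains a limit, not a number: the limit of > 200000 nM in this assay, at which 1 of the 4 values shown sits.

On these data alone, whether other acyl groups, such as benzoyl or thiophene-2-carbonyl, behave like compound 4 or like compound 3 stays open. So does the effect of a much shorter chain on the indole amide.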